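The source may hold more compounds than are shown below. What is called first, only, known or untested is meant among the compounds shown, and "the series" means these compounds.

Compound 1, `CC#CC(CC(=O)O)c1ccc(OCc2ccn3cc(-c4ccc(C(C)C)cc4)nc3c2)cc1`, gives 615 nM in an assay on isolated protein for agonist activity at Free fatty acid receptor 1 (Homo sapiens); on this read-out higher numbers stand for an effect only at larger amounts of compound and lower numbers for an effect already at smaller amounts.
Compound 2, `CC#CC(CC(=O)O)c1ccc(OCc2ccn3cc(-c4ccc(CC)cc4)nc3c2)cc1`, gives 671 nM.
Compound 3, `CC#CC(CC(=O)O)c1ccc(OCc2ccn3cc(-c4cccc(C)c4)nc3c2)cc1`, gives 1510 nM.

Among these three, compound 3 stands at the highest number, so its effect appears only at the largest amount of compound. Compounds 1 and 2 sit close together: a 1.1-fold higher number from compound 1 to compound 2 (0.04 log units; within the scatter). Moving from either of them to compound 3 raises the number: a 2.5-fold higher number from compound 1 to compound 3 (0.39 log units; beyond the scatter) and a 2.3-fold higher number from compound 2 to compound 3 (0.35 log units; beyond the scatter), both modest but beyond the scatter.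

Compound 4, `CC#CC(CC(=O)O)c1ccc(OCc2ccn3cc(-c4ccccc4C)nc3c2)cc1`, has not yet been measured. It differs from compound 3 in one place: 2-methylphenyl in place of 3-methylphenyl on an aromatic carbon. For the measured compounds named here, the two measured steps that bear on this change only show that a 3-methylphenyl gives a higher number than a 4-isopropylphenyl or a 4-ethylphenyl; no measured step moves a methyl from one place on the phenyl ring to another. The direction of the next step is therefore open. Given that the measured changes on this ring stayed modest, compound 4 is expected to show no step beyond the scatter, though the uncertainty is wide. For compound 4 the estimate in this assay is 2000 nM, with a range from 700 nM to 6000 nM. This estimate corresponds to a step of a 1.3-fold higher number from compound 3 to compound 4 (0.12 log units; within the scatter).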

Compound 4, half-maximal effective concentration: 459 nM
For compound 4 the middle estimate is 4.4-fold (0.64 log units) above the measured one; measured number outside the range, below it.
By their numbers in this assay, from the lowest: compounds 4, 1 and 2 (each within the scatter of the next); then compound 3.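

In this assay, the 3-methylphenyl and the 2-methylphenyl have the same atoms, yet exchanging one for the other gives a 3.3-fold lower number from compound 3 to compound 4 (0.52 log units; beyond the scatter), so the number at this position depends on where the methyl sits on the phenyl ring and not only on which atoms are present. The other two steps, a 1.5-fold lower number from compound 2 to compound 4 (0.16 log units; within the scatter) and a 1.3-fold lower number from compound 1 to compound 4 (0.13 log units; within the scatter), place compound 4 level with the 4-ethylphenyl and 4-isopropylphenyl compounds, which shows that the high number of compound 3 is not shared by every alkyl-substituted phenyl tested at this position. Nothing available here explains why the place of the methyl changes the number.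

The compounds shown leave open how a plain phenyl ring with no methyl would compare at this position, which would show whether the methyl of the 2-methylphenyl contributes anything at all. On these data alone, it also remains open whether a methoxy group or a chlorine in place of that methyl would give a number like that of compound 4.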